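Swapping 3,5-dichlorobenzyl for 4-chlorobenzyl: a small expected step

The source may hold more compounds than are shown below. What is called first, only, known or untested is meant among the compounds shown, and "the series" means these compounds.

In a functional assay on HCT-116 cells (Homo sapiens) for inhibition, read by sulforhodamine B assay, with a stated time of 72 h (on this read-out higher numbers stand for weaker inhibition of growth and lower numbers for stronger inhibition of growth), compound 1 (`O=C(NO)c1cnc(N2C[C@@H]3CN(S(=O)(=O)c4ccc5ccccc5c4)C[C@@H]3C2)nc1`) gives 740 nM and compound 2 (`O=C(NO)c1cnc(N2C[C@H]3CN(Cc4cc(Cl)cc(Cl)c4)C[C@H]3C2)nc1`) gives 530 nM so the two stand within the scatter of each other. Compound 3 (`O=C(NO)c1cnc(N2C[C@H]3CN(Cc4ccc(Cl)cc4)C[C@H]3C2)nc1`) has 4-chlorophenyl in place of 3,5-dichlorophenyl on a saturated chain carbon bound to an amine nitrogen in a ring. For the measured compounds named here, no measured pair shows this change. In this assay no shift beyond the scatter is expected, if anything a slightly higher number. The estimated step of a 1.2-fold higher number from compound 2 to compound 3 (0.09 log units; within the scatter) is therefore small. For compound 3 the expected value is 650 nM with an estimated range of 250 nM to 1700 nM as its likely span.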

Compound 3, concentration for 50% growth inhibition: 490 nM
Beside the measured number, compound 3's estimate is 1.3-fold (0.12 log units) above it; low and high end bracket the measured number.
By their numbers in this assay, from the lowest: compounds 3, 2 and 1 (each within the scatter of the next).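

In this assay the change gives a 1.1-fold lower number from compound 2 to compound 3 (0.03 log units; within the scatter) and so shows that, on a saturated chain carbon bound to an amine nitrogen in a ring, 4-chlorophenyl and 3,5-dichlorophenyl cannot be told apart. Going from two chlorines to one leaves the reading within the scatter. No measurement given here explains this result. As far as these compounds go, whether any chlorine is needed at this place stays open, as does how an amine or a carboxylic acid in its stead would read.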